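Protein binding notes: ring-to-chain change on the amide nitrogen

This account rests on a few compounds, and the source may have more. Where it says the series, first, only, none or still open, it means among the compounds named here.

Measured compounds in an ADME assay for protein binding, using equilibrium dialysis, at pH 7.4, tested at 2 uM; on this read-out lower numbers stand for a smaller free fraction and higher numbers for a larger free fraction:
compound 1 `CC1CC=C(C(=O)N(c2cc(C#CC(C)(C)C)sc2C(=O)O)C(C)C)CC1` — 0.08
compound 2 `CC(C)(C)C#Cc1cc(N(C(=O)[C@H]2CC[C@H](C)CC2)[C@H]2C[C@@H](Oc3cccnc3)C2)c(C(=O)O)s1` — 0.04
compound 3 `CC(C)N(c1cc(C#CC(C)(C)C)sc1C(=O)O)C(=O)[C@H]1CC[C@H](C)CC1` — 0.06

Compound 2 gives the smallest of the three numbers, yet nothing sets it apart beyond the scatter: the step of a 1.5-fold higher number from compound 2 to compound 3 (0.18 log units; within the scatter) is within it, and compound 1 with 0.08 lies equally near. The other step, a 1.3-fold lower number from compound 1 to compound 3 (0.12 log units; within the scatter), is also within the scatter.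

Compound 4 `C[C@@H](CCOc1cccnc1)N(c1cc(C#CC(C)(C)C)sc1C(=O)O)C(=O)[C@H]1CC[C@H](C)CC1` is not yet measured. It differs from compound 2 as 1-methyl-3-((pyridin-3-yl)oxy)propyl in place of 3-((pyridin-3-yl)oxy)cyclobutyl on an amide-type nitrogen. Among the measured compounds shown here, the only step at this nitrogen, a 1.5-fold higher number from compound 2 to compound 3 (0.18 log units; within the scatter), stayed within the scatter even when the whole pyridinyloxy group left; here it stays. For compound 4 a step of a 1.3-fold higher number from compound 2 to compound 4 (0.10 log units; within the scatter) is therefore expected, none beyond the scatter, with an estimated 0.05 and a range from 0.025 to 0.1.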

Compound 4, unbound fraction: 0.02
The estimate for compound 4 lay 2.5-fold (0.40 log units) above the measured number, and the stated range ends above it.
By their numbers in this assay, from the lowest: compounds 4, 2, 3 and 1 (each within the scatter of the next, the first and the last beyond it).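

On the amide-type nitrogen, 1-methyl-3-((pyridin-3-yl)oxy)propyl in place of 3-((pyridin-3-yl)oxy)cyclobutyl gives a 2.0-fold lower number from compound 2 to compound 4 (0.30 log units; within the scatter), so this assay does not separate these two groups. The step of a 3.0-fold lower number from compound 3 to compound 4 (0.48 log units; beyond the scatter), with ((pyridin-3-yl)oxy)methyl in place of hydrogen on a saturated chain carbon, is the first beyond the scatter among the compounds shown. No measurement on hand accounts for this step.

Open, going by these compounds, is whether a plain phenyl ether or an unsubstituted longer alkyl chain on this nitrogen would read like compound 4. Also open, on these data alone, is how the opposite configuration at its single defined chain stereocentre would read.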